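The compounds below may be only part of what the source reports. "The series", "measured", "known", "first", "only" and "open" are said of these compounds alone.

compound 1 `Cc1ccc(-c2nc3c(c(C)nn3-c3ccccc3)c(-c3ccccc3O)c2C#N)cc1`: 26000 nM
compound 2 `Cc1nn(-c2ccccc2)c2nc(-c3ccc(F)cc3)c(C#N)c(-c3ccccc3O)c12`: 6000 nM
compound 3 `Cc1nn(-c2ccccc2)c2nc(-c3ccc(I)cc3)c(C#N)c(-c3ccccc3O)c12`: 1500 nM

In a physicochemical assay for solubility, read by spectrophotometry, in phosphate buffer, with a stated time of 18 h, at pH 7.4 (on this read-out higher numbers stand for higher solubility and lower numbers for lower solubility), compound 3 stands lowest of the three, at 1500 nM on this scale. Compound 4 `Cc1nn(-c2ccccc2)c2nc(-c3ccc(S(C)(=O)=O)cc3)c(C#N)c(-c3ccccc3O)c12` is still unmeasured. It differs from compound 3 in one place: methylsulfonyl in place of iodo on an aromatic carbon. Two measured steps arrive at the same iodo compound: a 17-fold lower number from compound 1 to compound 3 (1.24 log units; beyond the scatter) and a 4.0-fold lower number from compound 2 to compound 3 (0.60 log units; beyond the scatter). Among the compounds with values here, both other groups tried at this place thus give higher numbers than iodo, yet methylsulfonyl itself has no measured precedent here. A modest rise in this assay is therefore expected, with wide uncertainty. The estimated change is a 4.0-fold higher number from compound 3 to compound 4 (0.60 log units; beyond the scatter) as expected here. Compound 4 is estimated at 6000 nM, with an expected range from 1500 nM to 25000 nM overall.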

Compound 4, solubility: 5000 nM
Beside the measured number, compound 4's estimate is 1.2-fold (0.08 log units) above it, within the range that was stated.
By their numbers in this assay, from the lowest: compound 3; then compounds 4 and 2 (each within the scatter of the next); then compound 1.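

In this assay this place on the ring accepts methylsulfonyl, a group with more heavy atoms than iodo and with hydrogen-bond acceptors, and the number still rises, with a 3.3-fold higher number from compound 3 to compound 4 (0.52 log units; beyond the scatter) as the step. Fluoro and methylsulfonyl cannot be told apart here, given a 1.2-fold lower number from compound 2 to compound 4 (0.08 log units; within the scatter) as their step, so two very different groups can land at one level, while a 5.2-fold lower number from compound 1 to compound 4 (0.72 log units; beyond the scatter) leaves the methyl compound highest of the four. Nothing available explains these differences. As far as these compounds go, whether an amine or a carboxylic acid at this place would match methyl remains open.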